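Swapping the Lactam Nitrogen Substituent: Aryl to Benzyl

The source may report more compounds than this note shows. Statements on the series, on what has been measured and on what is new or still open speak of the compounds shown alone.

Measured so far:
- compound 1, `O=c1oc2ccccc2n1Cc1nc(-c2cccc(Cl)c2)no1`: 2100 nM
- compound 2, `Cc1ccccc1N1CC(c2nc(-c3cccc(Cl)c3)no2)CC1=O`: 370 nM

Both compounds were tested in an in vitro functional assay on HEK293-A cells for negative allosteric modulation of metabotropic glutamate receptor 5 (Homo sapiens), read by FLIPR and calcium flux; on this read-out higher numbers stand for weaker inhibition and lower numbers for stronger inhibition. Compound 1 gives 2100 nM, while compound 2 gives 370 nM, which is the lower of the two numbers and a difference beyond the usual scatter, so compound 2 stands as the stronger inhibitor of this pair. Among the compounds with values here, the two compounds differ in more than one place, so no single-point step can be drawn between them.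

Compound 3, `O=C1CC(c2nc(-c3cccc(Cl)c3)no2)CN1Cc1ccc(F)cc1`, has not yet been measured. It differs from compound 2 in one place: 4-fluorobenzyl in place of 2-methylphenyl on an amide-type nitrogen in a ring. The group that leaves is 2-methylphenyl and the group that enters is 4-fluorobenzyl, both on the amide-type nitrogen in the ring.

Within the data shown here, with no single-point step available among the measured compounds, the expected size of the change is uncertain. Compound 3 is estimated at 800 nM, with a range from 250 nM to 3000 nM. This estimate corresponds to a step from compound 2 to compound 3 of a 2.2-fold higher number from compound 2 to compound 3 (0.33 log units; beyond the scatter), a modest weakening that may or may not exceed the scatter.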

Compound 3, half-maximal inhibitory concentration: 3600 nM
Estimate against measurement, compound 3: 4.5-fold (0.65 log units) below, outside the stated range (above it).
By their numbers in this assay, from the lowest: compound 2; then compounds 1 and 3 (each within the scatter of the next).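

In this assay, placing 4-fluorobenzyl instead of 2-methylphenyl on the amide-type nitrogen gives a 9.7-fold higher number from compound 2 to compound 3 (0.99 log units; beyond the scatter), the first clear sign that the group on this nitrogen can change how strongly these compounds inhibit the receptor. The size of the step stands out. The two groups share much on paper: each carries one six-membered aromatic ring of carbon only, with 0 hydrogen-bond donors, 0 hydrogen-bond acceptors and no net charge, so these shared counts alone do not predict the result. Nothing available here accounts for why the number moves this far.

Going by these compounds, this single step changes several things at once, as the methyl group leaves, a fluorine enters and the aromatic ring becomes a benzyl group rather than a phenyl group, so the contribution of each remains unknown. Plain benzyl, 4-fluorophenyl and 2-methylbenzyl on the same nitrogen would help to separate these changes, while plain phenyl or a longer chain ending in a phenyl ring would show how the number responds to the link between the nitrogen and the ring.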